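Bromo for chloro on the anilino ring of compound 2

The source may hold more compounds than are shown below. What is called first, only, known or untested is meant among the compounds shown, and "the series" means these compounds.

Measured so far:
compound 1 `Fc1cccc(-c2nc(Nc3ccccc3)c3cc(F)ccc3n2)c1`: 47600 nM
compound 2 `Fc1cccc(-c2nc(Nc3ccccc3Cl)c3cc(F)ccc3n2)c1`: a limit only

Compound 1 gives 47600 nM in a functional assay on U2OS cells (Homo sapiens) for cytotoxicity, read by MTT assay, with a stated time of 48 h; on this read-out higher numbers stand for weaker inhibition and lower numbers for stronger inhibition. Compound 2 gives > 50000 nM in this assay, and this is a limit of the assay, not a number (the limit of > 50000 nM in this assay, at which 1 of the 2 values shown sits). Compound 2 therefore stands at the weak end of what the assay can report, while compound 1 sits just inside the measurable range. Within the data shown here, the one step measured so far, an at least 1.0-fold higher number from compound 1 to compound 2 (0.02 log units; that floor lies within the scatter), is the replacement of hydrogen by chloro and stays within the scatter.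

Compound 3 `Fc1cccc(-c2nc(Nc3ccccc3Br)c3cc(F)ccc3n2)c1` differs from compound 2 by bromo in place of chloro on an aromatic carbon. Among the measured compounds shown here, no measured step covers a halogen swap of this kind; the only step at hand, an at least 1.0-fold higher number from compound 1 to compound 2 (0.02 log units; that floor lies within the scatter), is a change at the same carbon and shows no shift beyond the scatter. The expectation is no step beyond the scatter, a step that the limit leaves unreadable from compound 2 to compound 3, with compound 3 most likely again at the limit. The estimate for compound 3 is 60000 nM, range 25000 nM to 150000 nM.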

Compound 3, half-maximal inhibitory concentration: > 50000 nM
Compound 3 gave a limit, no number; the forecaster's own chance of this, stated with the estimate: 75%; the middle value does not contradict the limit.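

In this assay compound 3 gives > 50000 nM, which is a limit of the assay and not a number. Bromo in place of hydrogen on this aromatic carbon reads as an at least 1.0-fold higher number from compound 1 to compound 3 (0.02 log units; that floor lies within the scatter), so a second halogen at this place also shows no shift beyond the scatter. The step from chloro to bromo cannot be read, and the series now gathers at one limit, with compound 1 the only one of the three to carry a number: the limit of > 50000 nM in this assay, at which 2 of the 3 values shown sit.

Open, as far as these compounds go, is whether another group at this place, such as an amine or a methoxy group, gives a clearly lower number than compound 1 at 47600 nM. Also open, from the compounds shown here alone, is where compound 2 and compound 3 truly lie beyond the limit, and whether they differ from each other at all.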